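The compounds below may be only part of what the source reports. "The series", "measured", "known", "first", "only" and "open" are said of these compounds alone.

Measured compounds in an ADME assay on MT2 cells (Homo sapiens) for cytotoxicity; a lower number here means that less compound is tolerated, a higher number that more compound is tolerated:
compound 1, `COc1ccnc(Nc2ccc(Cl)c(OCC=C(C)C)c2)n1`: 9000 nM
compound 2, `CCOc1ccnc(Nc2ccc(Cl)c(OCC=C(C)C)c2)n1`: 19000 nM
compound 3, `CC(C)=CCOc1cc(Nc2ncccn2)ccc1Cl`: 2500 nM

Compound 1 stands second highest of the three numbers. Compound 2 sits nearest, a 2.1-fold higher number from compound 1 to compound 2 (0.32 log units; beyond the scatter), and compound 3 furthest, a 3.6-fold lower number from compound 1 to compound 3 (0.56 log units; beyond the scatter). Between the two outer members, a 7.6-fold lower number from compound 2 to compound 3 (0.88 log units; beyond the scatter). All three steps are modest, and all three concern a single group on the shared core away from the oxygen that carries the 3-methylbut-2-en-1-yl group.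

Compound 4, `COc1ccnc(Nc2ccc(Cl)c(Oc3ccc(C)cc3)c2)n1`, is not yet measured. Relative to compound 1 the change is 4-methylphenyl in place of 3-methylbut-2-en-1-yl on an oxygen on an aromatic ring. Among the compounds with values here, no measured step touches this oxygen on the aromatic ring; the three steps recorded so far vary a different part of the core. Within the data shown here, they show only that single-group exchanges have moved the half-maximal cytotoxic concentration by modest amounts, and they give no direction for an exchange at this oxygen. A modest step is therefore expected for compound 4 in this assay, with the direction left open and the estimate leaning slightly toward a lower number: a 1.3-fold lower number from compound 1 to compound 4 (0.11 log units; within the scatter). Compound 4 is expected to give 7000 nM, within 2500 nM to 20000 nM.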

Compound 4, half-maximal cytotoxic concentration: > 100000 nM
Compound 4 was reported as a limit (the forecaster's own chance of this, stated with the estimate: 10%); middle value at least 14-fold (1.15 log units) away from the limit.
By their numbers in this assay, from the lowest: compound 3; then compound 1; then compound 2. At a limit, above all of these: compound 4.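

In this assay compound 4 gives > 100000 nM, which is a limit of the assay and not a number: the limit of > 100000 nM in this assay, at which 1 of the 4 values shown sits.

Compound 1, compound 2 and compound 3 all carry 3-methylbut-2-en-1-yl on the oxygen on an aromatic ring, so this is the only step shown at that position, and it reads an at least 11-fold higher number from compound 1 to compound 4 (1.04 log units; beyond the scatter). It is large, whereas the hydrogen, methoxy and ethoxy exchanges elsewhere on the shared core gave only modest steps, so the group on this oxygen moves the half-maximal cytotoxic concentration further, and 4-methylphenyl in place of 3-methylbut-2-en-1-yl goes toward more compound being tolerated.

This single exchange removes the open chain and its double bond and brings in an aromatic ring all at once, so the two remain inseparable; a saturated 3-methylbutyl chain or an unsubstituted phenyl on the same oxygen would divide them. Going by these compounds, the limit leaves the full size of the step unfixed, and it stays open whether 4-methylphenyl on this oxygen has a like effect on the cores of compound 2 and compound 3.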